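This account rests on a few compounds, and the source may have more. Where it says the series, first, only, none or still open, it means among the compounds named here.

Measured so far in an assay on cells for displacement of a labelled ligand from Glucagon receptor (Homo sapiens), in the presence of a further agent that is not named here; on this read-out higher numbers stand for weaker inhibition and lower numbers for stronger inhibition: compound 1 `O=C(O)CCNC(=O)c1ccc(C(Oc2ccc(-n3cc(C(F)(F)F)cn3)cc2)C2CCC2)cc1` gives 700 nM; compound 2 `O=C(O)CCNC(=O)c1ccc(C(Oc2ccc(-n3cc(C(F)(F)F)cn3)cc2)C2CCCC2)cc1` gives 420 nM; compound 3 `CC(C)(C)C(Oc1ccc(-n2cc(C(F)(F)F)cn2)cc1)c1ccc(C(=O)NCCC(=O)O)cc1` gives 170 nM.

Compound 3 stands at the lowest number of the three. The nearest is compound 2, a 2.5-fold lower number from compound 2 to compound 3 (0.39 log units; beyond the scatter), and the furthest is compound 1, a 4.1-fold lower number from compound 1 to compound 3 (0.61 log units; beyond the scatter). Compound 4 `CC(C)CC(Oc1ccc(-n2cc(C(F)(F)F)cn2)cc1)c1ccc(C(=O)NCCC(=O)O)cc1` is not yet measured in this assay and differs from compound 3 by isobutyl in place of tert-butyl on a saturated chain carbon bound to an aromatic carbon and an oxygen on an aromatic ring. Every measured step concerns this same group: a 1.7-fold lower number from compound 1 to compound 2 (0.22 log units; within the scatter) stays within the scatter, while a 4.1-fold lower number from compound 1 to compound 3 (0.61 log units; beyond the scatter) and a 2.5-fold lower number from compound 2 to compound 3 (0.39 log units; beyond the scatter) are modest. Within the data shown here, no measured step leads from tert-butyl to an open chain, so the direction is uncertain. Given a 4.1-fold lower number from compound 1 to compound 3 (0.61 log units; beyond the scatter) and a 2.5-fold lower number from compound 2 to compound 3 (0.39 log units; beyond the scatter), both lowering the number into compound 3, a move back toward a higher number is expected for compound 4, a 2.1-fold higher number from compound 3 to compound 4 (0.31 log units; beyond the scatter). In this assay compound 4 is expected near 350 nM, between 120 nM and 1000 nM.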

Compound 4, inhibition constant: 549 nM
Compound 4: the middle estimate sits 1.6-fold (0.20 log units) below what was measured; the measured number falls inside the stated range.
By their numbers in this assay, from the lowest: compound 3; then compounds 2, 4 and 1 (each within the scatter of the next).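

In this assay, rearranging the same carbons from tert-butyl to isobutyl on the saturated chain carbon gives a 3.2-fold higher number from compound 3 to compound 4 (0.51 log units; beyond the scatter), so at this position the arrangement of the carbons matters and not just their count. Among these compounds, the open chain reads level with both rings, a 1.3-fold higher number from compound 2 to compound 4 (0.12 log units; within the scatter) and a 1.3-fold lower number from compound 1 to compound 4 (0.11 log units; within the scatter), leaving tert-butyl as the only one of these four groups that stands apart. Nothing available bears on the reason for this difference. Still open, on these data alone, is whether isopropyl or a 1-methylcyclopropyl group would hold the lower number of compound 3, and how a longer chain would read.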